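Adding a third methoxy on the carbonyl-side ring

The compounds below may be only part of what the source reports. "The series", "measured", "known", "first", "only" and "open" are said of these compounds alone.

Measured compounds:
compound 1, `COc1cc(-c2cc(/C=C/C(=O)c3ccc(Cl)c(Cl)c3)[nH]n2)cc(OC)c1OC`, 18200 nM
compound 2, `COc1ccc(-c2cc(/C=C/C(=O)c3cc(OC)c(OC)c(OC)c3)[nH]n2)cc1OC`, 1800 nM
compound 3, `COc1ccc(C(=O)/C=C/c2cc(-c3cc(OC)c(OC)c(OC)c3)n[nH]2)cc1OC`, 1840 nM

In a functional assay on M14 cells (Homo sapiens) for inhibition, read by sulforhodamine B assay, with a stated time of 48 h (a lower number here means a stronger inhibitor of growth, a higher number a weaker inhibitor of growth), compound 3 gives 1840 nM, the second highest of the three numbers. Its nearest neighbour is compound 2, whose value of 1800 nM lies within the scatter of compound 3, so the two cannot be ordered. Compound 1, with 18200 nM, stands well apart: a 9.9-fold lower number from compound 1 to compound 3 (1.00 log units; beyond the scatter), a step beyond the scatter.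

Compound 4, `COc1cc(C(=O)/C=C/c2cc(-c3cc(OC)c(OC)c(OC)c3)n[nH]2)cc(OC)c1OC`, differs from compound 3 in one place: methoxy in place of hydrogen on an aromatic carbon

Among the measured compounds shown here, no measured step covers this particular exchange. For the measured compounds named here, the one step at hand, from compound 1 to compound 3, concerns a different change on the carbonyl-side ring and is therefore only a loose guide. Compound 2, which carries three methoxy groups on its carbonyl-side ring, sits at the same level as compound 3 within the scatter, so the added methoxy is not expected to move the number far. The author estimates that a 1.2-fold lower number from compound 3 to compound 4 (0.09 log units; within the scatter), a step of no clear size beyond the scatter.

Compound 4 is thus expected to give about 1500 nM in this assay, with a range from 500 nM to 4500 nM.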

Compound 4, concentration for 50% growth inhibition: 1790 nM
For compound 4 the middle estimate is 1.2-fold (0.08 log units) below the measured one, within the range that was stated.
By their numbers in this assay, from the lowest: compounds 4, 2 and 3 (each within the scatter of the next); then compound 1.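

In this assay, methoxy in place of hydrogen on an aromatic carbon of the carbonyl-side ring, ortho to a methoxy group, gives a step within the scatter (a 1.0-fold lower number from compound 3 to compound 4 (0.01 log units; within the scatter)). Among the compounds shown here, this is the first direct reading at this position, and it shows that the third methoxy on that ring leaves the number indistinguishable from that of compound 3. The same exchange on the other aromatic ring also stays within the scatter (a 1.0-fold lower number from compound 2 to compound 4 (0.00 log units; within the scatter)), so compounds 2, 3 and 4 cannot be ordered, and the two steps show no difference between the rings for this exchange. No available evidence accounts for this result.

On these data alone, what remains open is whether an amine, a carboxylic acid or a longer chain such as ethoxy at this aromatic carbon would also stay within the scatter of compound 3. Also open, as far as these compounds go, is whether hydrogen in place of the neighbouring methoxy groups on this ring would do the same.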